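Swapping the methoxy of an amide side chain for azido

The compounds below may be only part of what the source reports. "The series", "measured", "known", "first", "only" and "open" are said of these compounds alone.

Measured compounds:
- compound 1, `COCC(=O)N(Cc1ccc(OC)c(O)c1)c1cc(OC)c(OC)c(OC)c1`, 230 nM
- compound 2, `C/C=C/C(=O)N(Cc1cccc(O)c1)c1cc(OC)c(OC)c(OC)c1`, 6700 nM

Both compounds share a core carrying a trimethoxyphenyl amide and were tested in a functional assay on HCT-116 cells (Homo sapiens) for inhibition, read by MTT assay, with a stated time of 48 h; on this read-out lower numbers stand for stronger inhibition and higher numbers for weaker inhibition. Of the two numbers, compound 1 has the lower one, and the gap between compound 1 and compound 2 lies beyond the usual scatter, so compound 1 is the stronger inhibitor among them. Compound 2 also differs from compound 1 in several places at once, so no single change can be read from that pair.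

Compound 3, `COc1ccc(CN(C(=O)CN=[N+]=[N-])c2cc(OC)c(OC)c(OC)c2)cc1O`, keeps everything in compound 1 except one group: azido in place of methoxy on a saturated chain carbon bound to a carbonyl carbon. For the measured compounds named here, no measured pair shows this change, so there is nothing to lean on. For compound 3 the expected step is a 1.3-fold higher number from compound 1 to compound 3 (0.12 log units; within the scatter), a change not expected to go beyond the scatter. Compound 3 is therefore estimated at 300 nM, with a likely range from 80 nM to 1200 nM.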

Compound 3, half-maximal inhibitory concentration: 410 nM
Compound 3: the middle estimate sits 1.4-fold (0.14 log units) below what was measured, and the stated range covers the measured number.
By their numbers in this assay, from the lowest: compounds 1 and 3 (each within the scatter of the next); then compound 2.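

In this assay, azido in place of methoxy on a saturated chain carbon bound to a carbonyl carbon gives a 1.8-fold higher number from compound 1 to compound 3 (0.25 log units; within the scatter) and this is the only single change that can be read among the compounds shown. On this read-out compound 1 and compound 3 cannot be told apart, so this position accepts azido, with its 3 nitrogen atoms, as well as methoxy, with its carbon and oxygen. Nothing on hand explains why the two groups read alike here.

On these data alone, what stays open is how far this tolerance extends: whether an amine or a carboxylic acid on the same chain carbon, or a longer chain in place of methoxymethyl, would keep the number in this range. One pair also cannot show whether the same swap would read alike on a different core.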